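Spiro ring exchange on the core of compound 2

The source may report more compounds than this note shows. Statements on the series, on what has been measured and on what is new or still open speak of the compounds shown alone.

Compound 1 `FC(F)(F)c1ccccc1-c1ccc2[nH]c(C3=NOC4(CCCCC4)C3)nc2c1` gives 3.1 nM in a functional assay on HEK293 cells for antagonist activity at transient receptor potential M8 protein (Canis lupus familiaris), read by FLIPR and calcium flux; on this read-out lower numbers stand for stronger inhibition and higher numbers for weaker inhibition. Compound 2 `FC(F)(F)c1ccccc1-c1cc(Cl)c2[nH]c(C3=NOC4(CCCCC4)C3)nc2c1` gives 3.3 nM and holds the highest of the three numbers; its step of a 1.1-fold higher number from compound 1 to compound 2 (0.03 log units; within the scatter) stays within the scatter, while compound 3 `OCCCc1cc(-c2ccccc2C(F)(F)F)cc2nc(C3=NOC4(CCCCC4)C3)[nH]c12` at 0.2 nM lies furthest away, through a 17-fold lower number from compound 2 to compound 3 (1.22 log units; beyond the scatter) and a 16-fold lower number from compound 1 to compound 3 (1.19 log units; beyond the scatter). Compound 4 `FC(F)(F)c1ccccc1-c1cc(Cl)c2[nH]c(C3=NOC4(CCOCC4)C3)nc2c1` differs from compound 2 by a group of 10 heavy atoms (7 carbon, 1 nitrogen, 2 oxygen; one five-membered non-aromatic ring with 2 hetero atoms, one six-membered non-aromatic ring with 1 hetero atom) in place of a group of 10 heavy atoms (8 carbon, 1 nitrogen, 1 oxygen; one five-membered non-aromatic ring with 2 hetero atoms, one six-membered non-aromatic ring of carbon only), on an aromatic carbon, on an aromatic carbon of the five-membered aromatic ring between two ring nitrogen atoms. The measured steps all concern the substituent on the six-membered aromatic ring, so none of them bears on this exchange. Compound 4 is therefore expected to stay close to compound 2, with an estimated step of a 1.2-fold higher number from compound 2 to compound 4 (0.08 log units; within the scatter). The estimate for compound 4 in this assay is 4 nM, in the range 1.5 nM to 12 nM.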

Compound 4, half-maximal inhibitory concentration: 4 nM
Compound 4: the middle estimate sits on the measured number at the digits printed, within the range that was stated.
By their numbers in this assay, from the lowest: compound 3; then compounds 1, 2 and 4 (each within the scatter of the next).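

In this assay, a six-membered non-aromatic ring with 1 hetero atom replaces the six-membered non-aromatic ring of carbon only, on the aromatic carbon between two ring nitrogen atoms, with a 1.2-fold higher number from compound 2 to compound 4 (0.08 log units; within the scatter). Among the compounds shown here, this is the first reading at this position, and it shows that, with chloro on the core, this ring exchange leaves the number within the scatter. No measurement bearing on this result is available to explain it. Still open, as far as these compounds go, is whether the exchange holds with the 3-hydroxypropyl group of compound 3 in place of chloro, and how an amine nitrogen in place of the ring oxygen would read.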